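The source may hold more compounds than are shown below. What is called first, only, known or untested is meant among the compounds shown, and "the series" means these compounds.

Measured compounds and their values in an ADME assay on L6 cells (Rattus norvegicus) for cytotoxicity, read by resazurin assay, with a stated time of 72 h; a higher number here means a weaker inhibitor, a lower number a stronger inhibitor:

compound 1 `CN(C)C12CC(c3ccccc3)C(CN(C(=O)CN3CCCC3)C1)C(c1ccccc1)C2`: 12600 nM
compound 2 `CN1CCN(CCC(=O)N2CC3C(c4ccccc4)CC(N(C)C)(CC3c3ccccc3)C2)CC1`: 13000 nM
compound 3 `CN(C)C12CC(c3ccccc3)C(CN(CCN3CCCCC3)C1)C(c1ccccc1)C2`: 2920 nM

Compound 3 has the lowest number of the three, and so is the strongest inhibitor in this assay: the step from compound 1 is a 4.3-fold lower number from compound 1 to compound 3 (0.63 log units; beyond the scatter), and the step from compound 2 is a 4.5-fold lower number from compound 2 to compound 3 (0.65 log units; beyond the scatter). Compound 1 and compound 2, which carry a carbonyl on the ring amine nitrogen, sit close together, the step between them being a 1.0-fold higher number from compound 1 to compound 2 (0.01 log units; within the scatter).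

Compound 4 `CN(C)C12CC(c3ccccc3)C(CN(CCCN3CCCCC3)C1)C(c1ccccc1)C2` differs from compound 3 in one place: (piperidin-1-yl)methyl in place of piperidin-1-yl on a saturated chain carbon, two bonds along the chain from an amine nitrogen in a ring. Among the compounds with values here, no measured step lengthens a chain in this way. The steps that do exist swap a carbonyl-bearing group for a plain chain or exchange the amine at the end of the carbonyl-bearing group, and the latter, compound 1 to compound 2, stays within the scatter. There is no basis in these numbers for expecting a large move in this assay in either direction, so compound 4 is expected to land near compound 3, with the estimated step being a 1.0-fold higher number from compound 3 to compound 4 (0.01 log units; within the scatter). For compound 4 the estimated value is 3000 nM, within a range from 1400 nM to 6500 nM.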

Compound 4, half-maximal inhibitory concentration: 1750 nM
Estimate against measurement, compound 4: 1.7-fold (0.23 log units) above; low and high end bracket the measured number.
By their numbers in this assay, from the lowest: compounds 4 and 3 (each within the scatter of the next); then compounds 1 and 2 (each within the scatter of the next).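

In this assay, within the data shown here, this is the first look at chain length on the ring amine nitrogen: going from 2-(piperidin-1-yl)ethyl to 3-(piperidin-1-yl)propyl gives a 1.7-fold lower number from compound 3 to compound 4 (0.22 log units; within the scatter) and so leaves the two compounds indistinguishable in this assay. The longer plain chain also keeps the gap to the carbonyl-bearing compounds beyond the scatter, with a 7.4-fold lower number from compound 2 to compound 4 (0.87 log units; beyond the scatter) and a 7.2-fold lower number from compound 1 to compound 4 (0.86 log units; beyond the scatter) as the two steps, so a plain chain at this nitrogen now gives lower numbers at both lengths, though each of these steps also changes the amine or the chain as well as removing the carbonyl. Nothing available here accounts for either the flat response to chain length or the gap to the carbonyl-bearing compounds.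

Still open, on these data alone, is whether a longer chain, such as 4-(piperidin-1-yl)butyl, would stay level with these two compounds or begin to shift the number. The end of the plain chain also remains to be explored, since only piperidin-1-yl appears there, and a morpholin-4-yl or a dimethylamino group in its place could behave differently.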